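This account rests on a few compounds, and the source may have more. Where it says the series, first, only, none or still open, it means among the compounds named here.

In a functional assay on CHO cells for agonist activity at Free fatty acid receptor 1 (Homo sapiens), read by calcium flux (on this read-out lower numbers stand for an effect already at smaller amounts and higher numbers for an effect only at larger amounts of compound), compound 1 `CO[C@H]1C[C@H](Oc2cc(F)c(F)c(-c3cc(C)c(OCCCC(=O)O)c(C)c3)c2)C1` gives only a limit, > 100000 nM, and not a number. Compound 2 `CO[C@H]1C[C@H](Oc2cc(F)c(F)c(-c3cc(F)c(SCCCC(=O)O)c(F)c3)c2)C1` likewise reaches only the limit of > 100000 nM in this assay. Compound 2 thus stands at the limit of > 100000 nM in this assay, at which 2 of the 2 values shown sit. Compound 3 `CO[C@H]1C[C@H](Oc2cc(F)c(F)c(-c3cc(F)c(OCCCCCCCC(=O)O)c(F)c3)c2)C1` is not yet measured; it differs from compound 2 in that ((7-carboxyheptyl)oxy in place of (3-carboxypropyl)sulfanyl on an aromatic carbon), a (7-carboxyheptyl)oxy chain taking the place of a (3-carboxypropyl)sulfanyl chain. Within the data shown here, no measured step between compounds is known, so any expectation rests on the two limits alone. The step from compound 2 to compound 3 in this assay is expected to be an at least 2.5-fold lower number from compound 2 to compound 3 (0.39 log units; beyond the scatter), with wide uncertainty. For compound 3 the estimate in this assay is 40000 nM, spanning 3000 nM to 300000 nM.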

Compound 3, half-maximal effective concentration: 3480 nM
For compound 3 the middle estimate is 11-fold (1.06 log units) above the measured one; low and high end bracket the measured number.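

In this assay, the chain on this aromatic carbon, ortho to two fluoro groups, decides whether a measurable response appears at all: (7-carboxyheptyl)oxy in place of (3-carboxypropyl)sulfanyl gives an at least 28-fold lower number from compound 2 to compound 3 (1.45 log units; beyond the scatter). The true size of this step stays open, as compound 2 gives only a limit: the limit of > 100000 nM in this assay, at which 2 of the 3 values shown sit.

The change alters both the linking atom and the chain length, so the compounds shown cannot separate the two effects. A (3-carboxypropyl)oxy or (7-carboxyheptyl)sulfanyl chain on the same core would separate them, and a still longer chain would show whether the trend continues.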